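This account rests on a few compounds, and the source may have more. Where it says the series, first, only, none or still open, it means among the compounds named here.

Measured compounds in the series:
compound 1, `O=C(Nc1ccc(OC(F)(F)F)cc1)NC1CCN(C(=O)[C@@H]2CCOC2)CC1`, gives 3.38
compound 2, `O=C(Nc1ccc(OC(F)(F)F)cc1)NC1CCN(C(=O)C2CCCOC2)CC1`, gives 3.42
compound 3, `O=C(Nc1ccc(C(F)(F)F)c(F)c1)NC1CCN(C(=O)C2CCCOC2)CC1`, gives 3.84

All three values come from a physicochemical assay for lipophilicity, read by HPLC, with a stated time of 90 min, tested at 100 uM; a higher number here means a more lipophilic compound, a lower number a more polar compound. Compound 1 and compound 2 share a core and differ only by oxolan-3-yl in place of oxan-3-yl on a carbonyl carbon; that change made a number 0.04 log units lower from compound 2 to compound 1 (within the scatter). Compound 3 stands highest of the three numbers, with the nearest being compound 2 and the furthest compound 1, both beyond the scatter. The difference between the core of compound 3 and the core of compound 2 is not broken down here.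

Compound 4, `O=C(Nc1ccc(C(F)(F)F)c(F)c1)NC1CCN(C(=O)[C@@H]2CCOC2)CC1`, has not yet been measured. It differs from compound 3 by oxolan-3-yl in place of oxan-3-yl on a carbonyl carbon, and the surroundings of the place are the same as for the change from compound 2 to compound 1, so this is the same change made a second time. The expected step from compound 3 to compound 4 is a number 0.04 log units lower from compound 3 to compound 4 (within the scatter), resting on the earlier step because a number 0.04 log units lower from compound 2 to compound 1 (within the scatter) lay within the scatter. Compound 4 is therefore estimated at 3.8 in this assay, with a range from 3.55 to 4.05.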

Compound 4, partition coefficient: 3.41
Compound 4: middle estimate off by 0.39 log units, on the high side; the measured number lies below the stated range.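

In this assay, placing oxolan-3-yl where oxan-3-yl stood on a carbonyl carbon gave a number 0.43 log units lower from compound 3 to compound 4 (beyond the scatter) on one core, against a number 0.04 log units lower from compound 2 to compound 1 (within the scatter) on the other, so one step lies beyond the scatter and the other within it. The change therefore does not carry over at a single size between these two cores, though two pairs do not show which part of the cores matters or how the change would read on a further core. No measurement in hand accounts for the difference between the two steps.

Still open, going by these compounds, is whether a third core, such as one carrying a nitrile in place of trifluoromethyl, would follow either step. The compounds shown carry only oxan-3-yl and oxolan-3-yl on the carbonyl carbon, so how an amine or a carboxylic acid at that place would read in this assay also remains open.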